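A few compounds are considered here, and "the series" means these few. Any claim that something is new, unique, unknown or untested is made for them only; others in the source may bear on it.

Measured so far in a functional assay on I10 cells (Mus musculus) for inhibition, read by MTT assay, with a stated time of 72 h; on this read-out lower numbers stand for stronger inhibition and higher numbers for weaker inhibition
- compound 1 `C=CCc1ccc(OCc2ccc(Cl)cc2Cl)c(-c2ccc(O)c(CC=C)c2)c1` gives 21100 nM
- compound 2 `C=CCc1ccc(OCc2ccc(Cl)c(Cl)c2)c(-c2ccc(O)c(CC=C)c2)c1` gives 12200 nM
- compound 3 `C=CCc1ccc(OCc2c(Cl)cccc2Cl)c(-c2ccc(O)c(CC=C)c2)c1` gives 17200 nM

Compound 3 lies within the scatter of both other compounds, with a 1.2-fold lower number from compound 1 to compound 3 (0.09 log units; within the scatter) and a 1.4-fold higher number from compound 2 to compound 3 (0.15 log units; within the scatter) as its two steps. The next compound is compound 4 `C=CCc1ccc(OCc2ccccc2)c(-c2ccc(O)c(CC=C)c2)c1`, which differs from compound 3 by phenyl in place of 2,6-dichlorophenyl on a saturated chain carbon bound to an oxygen on an aromatic ring as phenyl in place of 2,6-dichlorophenyl on a saturated chain carbon bound to an oxygen on an aromatic ring.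

The third measured step, a 1.7-fold lower number from compound 1 to compound 2 (0.24 log units; within the scatter) as well, also stays within the scatter. All three steps bear on this place, but each only exchanges one dichlorophenyl for another. None replaces a dichlorophenyl with phenyl, so the evidence is indirect and the range is kept wide. In this assay no change beyond the scatter is expected, and the estimated step is a 1.1-fold higher number from compound 3 to compound 4 (0.04 log units; within the scatter) on this reading. For compound 4 the estimated value is 19000 nM with an expected range from 8000 nM to 42000 nM in this assay.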

Compound 4, half-maximal inhibitory concentration: 21800 nM
Beside the measured number, compound 4's estimate is 1.1-fold (0.06 log units) below it; the range from low to high includes it.
By their numbers in this assay, from the lowest: compounds 2, 3, 1 and 4 (each within the scatter of the next).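

In this assay, for the compounds shown here, the unsubstituted phenyl gives the first direct comparisons with each dichlorophenyl group: a 1.3-fold higher number from compound 3 to compound 4 (0.10 log units; within the scatter), a 1.8-fold higher number from compound 2 to compound 4 (0.25 log units; within the scatter) and a 1.0-fold higher number from compound 1 to compound 4 (0.01 log units; within the scatter), all within the scatter. On a saturated chain carbon bound to an oxygen on an aromatic ring, the chlorine atoms can therefore be absent without a change beyond the scatter, and neither their presence nor their arrangement separates these four compounds in this assay. No supporting measurement bears on this flat result.

On these data alone, it remains open whether a group of another kind at this place, such as an amine, a carboxylic acid or a longer chain in place of the phenyl, would move the number beyond the scatter. Also open, as far as these compounds go, is whether the same flat result would hold with a changed core.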